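A few compounds are considered here, and "the series" means these few. Any claim that something is new, unique, unknown or untested is made for them only; others in the source may bear on it.

Measured in an ADME assay (liver) for metabolic stability, with Liver microsome (Homo sapiens) as the target, using microsomes, tested at 1 uM; a higher number here means faster removal of the compound, a lower number slower removal:
- Compound 1 `COc1ccc2c(c1O)CCCC=C2c1cc(OC)c(OC)c(OC)c1`: 54.1 mL.min-1.g-1
- Compound 2 `COc1ccc2c(c1O)CCCC(CCCC#N)=C2c1cc(OC)c(OC)c(OC)c1`: 239 mL.min-1.g-1

Of these two, compound 2 has the higher number. Compound 3 `COc1ccc2c(c1O)CCCC(C)=C2c1cc(OC)c(OC)c(OC)c1` differs from it by one change: hydrogen in place of 2-cyanoethyl on a saturated chain carbon bound to a double-bonded ring carbon. In words, this is hydrogen in place of 2-cyanoethyl on a saturated chain carbon bound to a double-bonded ring carbon, so 3-cyanopropyl becomes methyl. Among the measured compounds shown here, only one measured step bears on this: a 4.4-fold higher number from compound 1 to compound 2 (0.65 log units; beyond the scatter), where 3-cyanopropyl replaced hydrogen. Shortening that chain should partly reverse the step, so a lower number is expected in this assay. The expected change is a 2.4-fold lower number from compound 2 to compound 3 (0.38 log units; beyond the scatter). Compound 3 is estimated at 100 mL.min-1.g-1, with an expected range of 45 mL.min-1.g-1 to 220 mL.min-1.g-1.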

Compound 3, intrinsic clearance in microsomes: 108 mL.min-1.g-1
The estimate for compound 3 lay 1.1-fold (0.03 log units) below the measured number; measured number inside the range.
By their numbers in this assay, from the lowest: compounds 1 and 3 (each within the scatter of the next); then compound 2.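

In this assay the change from 3-cyanopropyl to methyl gives a 2.2-fold lower number from compound 2 to compound 3 (0.34 log units; beyond the scatter) and shows that the higher number of compound 2 depends on the part of the chain beyond methyl. Methyl in place of hydrogen on a double-bonded ring carbon gives a 2.0-fold higher number from compound 1 to compound 3 (0.30 log units; within the scatter) and so cannot be told apart from hydrogen here. No measurement at hand explains these differences.

From the compounds shown here alone, whether chain length or the nitrile carries the effect stays open: a plain propyl chain, or a chain ending in an amine or a carboxylic acid, would help separate the two.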